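This account rests on a few compounds, and the source may have more. Where it says the series, first, only, none or still open, it means among the compounds named here.

Measured so far in a functional assay on MGC-803 cells (Homo sapiens) for inhibition, read by sulforhodamine B assay, with a stated time of 72 h, tested at 10 uM; a higher number here means more inhibition at the concentration tested (going by the name of the read-out), a lower number less inhibition:
compound 1 `Cc1cc(Nc2ccc(C(=O)/C=C/c3cccc(Br)n3)cc2)n2nc(SCc3ccc(Cl)cc3)nc2n1` gives 90.2%
compound 2 `Cc1cc(Nc2ccc(C(=O)/C=C/c3cccc(Br)n3)cc2)n2nc(SCc3ccc(C(F)(F)F)cc3)nc2n1` gives 96.6%

Compound 2 stands highest of the two numbers, with compound 1 nearest, the step being a number 6.4 percentage points higher from compound 1 to compound 2 (within the scatter). Compound 3 `Cc1cc(Nc2ccc(C(=O)/C=C/c3cccc(Br)n3)cc2)n2nc(SCCCc3ccccc3)nc2n1` is not yet measured. It differs from compound 2 by phenethyl in place of 4-(trifluoromethyl)phenyl on a saturated chain carbon bound to a sulfur. Within the data shown here, the one measured step concerns a substituent on the aromatic ring, not the chain, so it bears only loosely on this change, and it was within the scatter. No step beyond the scatter is therefore expected in this assay, though the high level of compound 2 leaves little room upward. The estimate for compound 3 is 88% (range 70% to 98%), a step of a number 8.6 percentage points lower from compound 2 to compound 3 (within the scatter).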

Compound 3, a percentage reported as inhibition, at one concentration (the size of the read-out at that concentration, not a potency): 76.7%
Beside the measured number, compound 3's estimate is 11.3 percentage points above it; the measured number falls inside the stated range.
By their numbers in this assay, from the lowest: compound 3; then compounds 1 and 2 (each within the scatter of the next).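

In this assay the group on the saturated chain carbon bound to a sulfur now shows a step beyond the scatter, which the ring substituent change did not. Phenethyl in place of 4-(trifluoromethyl)phenyl gives a number 19.9 percentage points lower from compound 2 to compound 3 (beyond the scatter) and phenethyl in place of 4-chlorophenyl gives a number 13.5 percentage points lower from compound 1 to compound 3 (beyond the scatter) in the same direction. Nothing available explains this drop.

Open, on these data alone, is whether the longer chain or the loss of the ring substituent carries it, which an unsubstituted benzyl would separate. Also open, as far as these compounds go, is how an amine on the chain would read.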